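This account rests on a few compounds, and the source may have more. Where it says the series, first, only, none or still open, it means among the compounds named here.

Measured compounds in a functional assay on NUGC-3 cells (Homo sapiens) for antiproliferative activity, read by sulforhodamine B assay; a higher number here means a weaker inhibitor of growth, a lower number a stronger inhibitor of growth:

Compound 1, `CCCCCCOc1cccc(O)c1C(=O)/C=C/c1ccc(O)cc1`: compound 1 gives > 30000 nM, which is a limit of the assay.
Compound 2, `O=C(/C=C/c1ccc(O)cc1)c1c(O)cccc1OCc1ccccc1`: compound 2 gives > 30000 nM, also a limit.
Compound 3, `O=C(/C=C/c1ccc(O)cc1)c1c(O)cccc1OCCC1CCCCC1`: compound 3 gives > 30000 nM, also a limit.

Within the data shown here, compound 1 stands only at a limit in this assay, and the other two values are limits as well, so no compound can be placed relative to another. The steps measured among them, a step that the two limits leave unreadable from compound 1 to compound 2, a step that the two limits leave unreadable from compound 1 to compound 3 and a step that the two limits leave unreadable from compound 2 to compound 3, are all unreadable because of the limit of > 30000 nM in this assay, at which 3 of the 3 values shown sit.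

The new compound is compound 4, `CC(C)CCOc1cccc(O)c1C(=O)/C=C/c1ccc(O)cc1`. It differs from compound 1 by isopropyl in place of butyl on a saturated chain carbon, two bonds along the chain from an oxygen on an aromatic ring. The variations at the same place in compounds 2 and 3, which reach groups of quite different shape on the chain bound to the ring oxygen, all end at the same limit, and the change to compound 4 is the smallest of them. Among the measured compounds shown here, no step in this assay can therefore be expected beyond the scatter; compound 4 is expected to remain at the limit.

Estimated for compound 4 in this assay: 45000 nM, range 15000 nM to 150000 nM. The expected step from compound 1 is a step that the limit leaves unreadable from compound 1 to compound 4.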

Compound 4, concentration for 50% growth inhibition: 12400 nM
The estimate for compound 4 lay 3.6-fold (0.56 log units) above the measured number, and the stated range ends above it.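

In this assay, among these compounds, compound 4 gives the only readable number among the four, so a change on this chain can move the compound off the limit, here by an at least 2.4-fold lower number from compound 1 to compound 4 (0.38 log units; beyond the scatter). The same holds against the other two chains, with an at least 2.4-fold lower number from compound 3 to compound 4 (0.38 log units; beyond the scatter) and an at least 2.4-fold lower number from compound 2 to compound 4 (0.38 log units; beyond the scatter), so isopropyl at this place on a saturated chain carbon, two bonds along the chain from an oxygen on an aromatic ring, separates compound 4 from the butyl and cyclohexyl variants and from the phenyl variant, whose chain is one carbon shorter. Each of these three steps gives only a minimum size: the limit of > 30000 nM in this assay, at which 3 of the 4 values shown sit.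

The steps among compound 1, compound 2 and compound 3 cannot be read, so those three chains cannot be ordered. From the compounds shown here alone, whether a shorter ethyl chain, or a chain ending in an amine or a carboxylic acid, would also give a readable number stays open.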